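From a hydroxyethyl side chain to a chlorophenylethyl group

The source may hold more compounds than are shown below. What is called first, only, known or untested is meant among the compounds shown, and "the series" means these compounds.

Compound 1 `C[C@H](c1ccc(F)cc1)N(Cc1cccc(CC(=O)O)c1)C(=O)c1cnc2ccccc2c1` was tested in an assay on CHO T-rex cells for antagonist activity at transient receptor potential cation channel subfamily M member 8 (Homo sapiens), read by calcium flux, with a stated time of 20 min; on this read-out higher numbers stand for weaker inhibition and lower numbers for stronger inhibition; in this assay compound 1 returns only a limit, > 3240 nM. Compound 2 `O=C(O)c1cccc(CN(C(=O)c2cnc3ccccc3c2)[C@H](CO)c2ccccc2)c1` likewise returns only a limit in this assay, > 6860 nM. Compound 2 thus stands at a limit, shown by the limit of > 6860 nM in this assay, at which 1 of the 2 values shown sits. The one other value available is also a limit, shown by the limit of > 3240 nM in this assay, at which 1 of the 2 values shown sits. Among the compounds with values here, neither compound yields a measured number, so no step between measured compounds can be stated. Compound 3 `C[C@H](c1cccc(Cl)c1)N(Cc1cccc(C(=O)O)c1)C(=O)c1cnc2ccccc2c1` differs from compound 2 by 1-(3-chlorophenyl)ethyl in place of 2-hydroxy-1-phenylethyl on an amide-type nitrogen. Within the data shown here, with no measured step to rest on, the direction of this change is open: a move beyond the usual scatter in either direction cannot be excluded, and a result that is again only a limit is just as plausible. Compound 3 is expected to give about 3500 nM, within a range from 600 nM to 20000 nM. That estimate is expected to mean a step of an at least 1.9-fold lower number from compound 2 to compound 3 (0.29 log units; that floor lies within the scatter).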

Compound 3, half-maximal inhibitory concentration: 62 nM
Beside the measured number, compound 3's estimate is 56-fold (1.75 log units) above it, and the stated range ends above it.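

Replacing 2-hydroxy-1-phenylethyl with 1-(3-chlorophenyl)ethyl on an amide-type nitrogen gives, in this assay, an at least 110-fold lower number from compound 2 to compound 3 (2.04 log units; beyond the scatter), so this position can carry a change well beyond the usual scatter. That size is only a floor, since compound 2 gives a limit and not a number: the limit of > 6860 nM in this assay, at which 1 of the 3 values shown sits. The exchange takes away the hydroxyl and brings in the chlorine in a single move, so the step belongs to the whole group and cannot be divided between those two parts.

The compounds shown leave open which part carries the step, and a plain 1-phenylethyl group on the same nitrogen would help to separate them. Also open, on these data alone, is how other ring substituents, such as a methoxy group or a bromine in place of the chlorine, would read at this position.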